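Removing One Chloro Group on Two Related Cores

The source may hold more compounds than are shown below. What is called first, only, known or untested is meant among the compounds shown, and "the series" means these compounds.

Three compounds have been measured so far:
Compound 1 `Cn1cncc1C(OCc1ccc(C#N)cc1-c1cccc(Cl)c1)c1ccc(C#N)nc1`: 8620 nM
Compound 2 `Cn1cncc1C(OCc1ccc(C#N)nc1-c1cc(Cl)cc(Cl)c1)c1ccc(C#N)cc1`: 1400 nM
Compound 3 `Cn1cncc1C(OCc1ccc(C#N)cc1-c1cc(Cl)cc(Cl)c1)c1ccc(C#N)nc1`: 960 nM

All three were tested in an assay on isolated protein (Bos taurus) for inhibition of geranylgeranyl transferase type-1 subunit beta (Homo sapiens); on this read-out lower numbers stand for stronger inhibition and higher numbers for weaker inhibition. Compound 3 and compound 1 differ by a single change, (hydrogen in place of chloro on an aromatic carbon), and this gives a 9.0-fold higher number from compound 3 to compound 1 (0.95 log units; beyond the scatter), a loss that lies beyond the scatter. Compound 2 and compound 3 are built from the same atoms joined differently; the difference between their two cores is not broken down here. In this assay compound 2 gives 1400 nM and compound 3 gives 960 nM, a gap that lies within the scatter. Compound 4 `Cn1cncc1C(OCc1ccc(C#N)nc1-c1cccc(Cl)c1)c1ccc(C#N)cc1` has not yet been measured. It arises from compound 2 by hydrogen in place of chloro on an aromatic carbon, the same change that separates compound 3 from compound 1. That earlier step was a 9.0-fold higher number from compound 3 to compound 1 (0.95 log units; beyond the scatter). Resting on that step, compound 4 is expected to show an 8.6-fold higher number from compound 2 to compound 4 (0.93 log units; beyond the scatter). Compound 4 is thus estimated at 12000 nM, between 5000 nM and 30000 nM.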

Compound 4, half-maximal inhibitory concentration: 1700 nM
Compound 4: middle estimate off by 7.1-fold (0.85 log units), on the high side, outside the stated range (below it).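

In this assay, the change from 3,5-dichlorophenyl to 3-chlorophenyl gives a 1.2-fold higher number from compound 2 to compound 4 (0.08 log units; within the scatter), so on this core the loss of the chloro group leaves no effect that can be told from the scatter. The same change therefore does not carry over with the same size from one core to the other: the same change on two cores in this assay, a 9.0-fold higher number (0.95 log units; beyond the scatter) from compound 3 to compound 1 and a 1.2-fold higher number (0.08 log units; within the scatter) from compound 2 to compound 4, 7.4-fold (0.87 log units) apart, beyond the scatter of two such steps. This shows that the step cannot simply be transferred between these two cores, but it does not show which difference between the cores is responsible, and two pairs give no rule for the rest of the series.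

The compounds shown leave open how either core would respond if a fluoro or methyl group stood in place of the chloro group. They also leave open what would happen on each core if the remaining chloro group gave way to hydrogen as well.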